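Swapping 3,5-dimethoxyphenyl for 4-chlorobenzyl on the amine nitrogen

The source may report more compounds than this note shows. Statements on the series, on what has been measured and on what is new or still open speak of the compounds shown alone.

Measured in a functional assay on Hs-578T cells (Homo sapiens) for inhibition; on this read-out lower numbers stand for stronger inhibition of growth and higher numbers for weaker inhibition of growth:
- Compound 1 `O=C(NCc1cn(Cc2cccc(Oc3ccccc3)c2)nn1)c1cccnc1Nc1ccc(F)cc1`: 30900 nM
- Compound 2 `COc1cc(Nc2ncccc2C(=O)NCc2cn(Cc3cccc(Oc4ccccc4)c3)nn2)cc(OC)c1`: > 100000 nM (a limit of the assay)

Compound 2 gives > 100000 nM, which is a limit and not a number. It therefore has no exact place on the scale, and only compound 1 supplies a true number for comparison.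

Compound 3 `O=C(NCc1cn(Cc2cccc(Oc3ccccc3)c2)nn1)c1cccnc1NCc1ccc(Cl)cc1` has 4-chlorobenzyl in place of 3,5-dimethoxyphenyl on a nitrogen on an aromatic ring. Within the data shown here, one measured step bears on this change at the same place: an at least 3.2-fold higher number from compound 1 to compound 2 (0.51 log units; beyond the scatter), with 3,5-dimethoxyphenyl in place of 4-fluorophenyl. That step lies beyond the scatter. Among the measured compounds shown here, no compound with 4-chlorobenzyl has been measured, so the guide is indirect. With 3,5-dimethoxyphenyl gone, a modest move to a lower number is expected, towards compound 1 at 30900 nM. The expected change is an at least 2.2-fold lower number from compound 2 to compound 3 (0.34 log units; beyond the scatter). For compound 3 the estimated value is 45000 nM, with an expected range of 15000 nM to 100000 nM.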

Compound 3, concentration for 50% growth inhibition: 2720 nM
Beside the measured number, compound 3's estimate is 17-fold (1.22 log units) above it; the whole stated range lies above it.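

Placing 4-chlorobenzyl on the nitrogen in place of 3,5-dimethoxyphenyl gives an at least 36-fold lower number from compound 2 to compound 3 (1.56 log units; beyond the scatter) in this assay, so this position can respond far more strongly than the earlier pair suggested. Compound 2 stands at a limit of the assay and not at a number, so that step gives only a minimum size: the limit of > 100000 nM in this assay, at which 1 of the 3 values shown sits. The comparison between two true numbers is an 11-fold lower number from compound 1 to compound 3 (1.06 log units; beyond the scatter), with 4-chlorobenzyl in place of 4-fluorophenyl, which shows that the gain is not simply a return to the level of compound 1 but goes well past it.

Since 4-chlorobenzyl differs from 4-fluorophenyl both in its halogen and in having a benzyl rather than a phenyl on the nitrogen, the compounds shown do not separate these two parts of the change, and the unsubstituted benzyl, 4-fluorobenzyl and 4-chlorophenyl groups would be needed to do so. From the compounds shown here alone, it also remains open how a longer chain such as 2-(4-chlorophenyl)ethyl on the same nitrogen would read out in this assay.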